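Enantiomeric cyclopropane carboxamides tested for cytotoxicity

A few compounds are considered here, and "the series" means these few. Any claim that something is new, unique, unknown or untested is made for them only; others in the source may bear on it.

Compound 1 `COc1cc([C@@H]2C[C@@]2(CO)C(=O)Nc2ccccc2)cc(OC)c1OC` — 76800 nM
Compound 2 `COc1cc([C@H]2C[C@]2(CO)C(=O)NCc2ccc(C)cc2)cc(OC)c1OC` — 94000 nM
Compound 3 `COc1cc([C@@H]2C[C@@]2(CO)C(=O)NCc2ccc(C)cc2)cc(OC)c1OC` — 76300 nM

Three compounds sharing one core were measured in a functional assay on SW480 cells (Homo sapiens) for cytotoxicity, read by MTT assay, with a stated time of 48 h; on this read-out lower numbers stand for stronger inhibition and higher numbers for weaker inhibition. Compound 3 differs from compound 2 only in configuration (the two compounds have the same atoms and bonds and differ only in configuration as drawn: 2 of 2 stereo elements differ (all stereocentres are inverted: mirror images); a stereocentre at a saturated ring carbon is drawn S in compound 3 and R in compound 2; a stereocentre at a saturated ring carbon is drawn R in compound 3 and S in compound 2), and the step of a 1.2-fold lower number from compound 2 to compound 3 (0.09 log units; within the scatter) lies within the scatter; the two values sit close together, a fact that rests on (the fact that compounds 2 and 3 differ only in the configuration as drawn). Compound 1 is derived from compound 3 by phenyl in place of 4-methylbenzyl on an amide-type nitrogen; the step of a 1.0-fold higher number from compound 3 to compound 1 (0.00 log units; within the scatter) also lies within the scatter, so the amide substituent change left the read-out essentially unchanged in that pair.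

Compound 4 `COc1cc([C@H]2C[C@]2(CO)C(=O)Nc2ccccc2)cc(OC)c1OC` has not yet been measured in this assay. It stands to compound 2 as compound 1 stands to compound 3: the change is phenyl in place of 4-methylbenzyl on an amide-type nitrogen, the same kind of change at the same place on an amide-type nitrogen. Because the step of a 1.0-fold higher number from compound 3 to compound 1 (0.00 log units; within the scatter) was flat, compound 4 is expected to land near compound 2, with an estimated step of a 1.0-fold lower number from compound 2 to compound 4 (0.02 log units; within the scatter). The estimate for compound 4 is 90000 nM, expected to fall between 45000 nM and 180000 nM.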

Compound 4, half-maximal inhibitory concentration: > 100000 nM
Compound 4: only a limit was reported (the forecaster's own chance of this, stated with the estimate: 20%); at least 1.1-fold (0.04 log units) between middle value and limit.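

In this assay compound 4 gave only a limit, > 100000 nM, and not a number. Phenyl in place of 4-methylbenzyl on an amide-type nitrogen gives an at least 1.0-fold higher number from compound 2 to compound 4 (0.02 log units; that floor lies within the scatter), so nothing here shows that the change behaves differently in the two configurations, but nothing shows that it carries over unchanged either: the same change on two cores in this assay, a 1.0-fold higher number (0.00 log units; within the scatter) from compound 3 to compound 1 and an at least 1.0-fold higher number (0.02 log units; that floor lies within the scatter) from compound 2 to compound 4; the limit leaves it open whether they differ The step between the mirror images, an at least 1.3-fold higher number from compound 1 to compound 4 (0.11 log units; that floor lies within the scatter), is likewise only a floor, so the size of any effect of configuration in this phenyl pair stays unknown, as does the true size of the change on the core of compound 2: the limit of > 100000 nM in this assay, at which 1 of the 4 values shown sits.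

The compounds shown leave open how far the read-out of compound 4 lies from that of compound 2, and whether it would separate from compound 1 if a number were available. They also leave open whether a longer chain, an amine or a carboxylic acid in that place on an amide-type nitrogen would move the read-out in either configuration.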